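The compounds below may be only part of what the source reports. "The series", "measured", "known", "first", "only" and "open" are said of these compounds alone.

In a functional assay on MT4 cells (Homo sapiens) for cytotoxicity (a higher number here means that more compound is tolerated, a lower number that less compound is tolerated), two related compounds have been tested so far. Compound 1 `Cc1c(O)nc(SCC(=O)c2ccc(F)cc2)nc1Cc1cccc2ccccc12` is reported only as a limit of the assay, >= 275000 nM. Among the measured compounds shown here, compound 2 `CCc1c(O)nc(SCC(=O)c2ccc(OC)cc2)nc1Cc1cccc2ccccc12` gives 178000 nM, the only true number available, so it has no measured neighbour to be ranked against. Compound 3 `CCc1c(O)nc(SCC(=O)c2ccc(F)cc2)nc1Cc1cccc2ccccc12` differs from compound 2 in one place, with fluoro in place of methoxy on an aromatic carbon, para to a large group: fluoro in place of methoxy on an aromatic carbon. This turns 4-methoxyphenyl into 4-fluorophenyl. For the measured compounds named here, no measured step isolates this change. Going by the values given here, the only hint comes from compound 1, which also carries 4-fluorophenyl and stands at the limit of >= 275000 nM in this assay, at which 1 of the 2 values shown sits. Little change beyond the usual scatter in this assay is therefore expected, with any drift towards more compound tolerated. The estimated step of a 1.2-fold higher number from compound 2 to compound 3 (0.07 log units; within the scatter) is expected to be small. Compound 3 is estimated at 210000 nM, within an expected range of 100000 nM to 400000 nM.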

Compound 3, half-maximal cytotoxic concentration: >= 240000 nM
Compound 3 was reported as a limit; the forecaster's own chance of this, stated with the estimate: 40%; at least 1.1-fold (0.05 log units) between middle value and limit.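

In this assay compound 3 gives >= 240000 nM, which is a limit of the assay and not a number. Fluoro in place of methoxy on the aromatic carbon, para to a large group, now has a first measured step, an at least 1.3-fold higher number from compound 2 to compound 3 (0.12 log units; that floor lies within the scatter), though this is only a floor and does not by itself separate the two compounds. The other step, methyl in place of hydrogen on a saturated chain carbon bound to an aromatic carbon, cannot be read, as compound 1 and compound 3 are both reported as limits.

On these data alone, the true size of the change from 4-methoxyphenyl to 4-fluorophenyl stays open, as the distance of compound 3 from its limit is unknown. Also open, as far as these compounds go, is how an amine or a carboxylic acid at this same place would read in this assay.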